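A few compounds are considered here, and "the series" means these few. Any claim that something is new, unique, unknown or untested is made for them only; others in the source may bear on it.

Within the data shown here, in a functional assay on PA-1 cells (Homo sapiens) for cytotoxicity, read by MTT assay, with a stated time of 72 h (a higher number here means a weaker inhibitor, a lower number a stronger inhibitor), compound 2 `C#CCn1cc(C(=O)NC(CC(=O)Nc2ccccc2)c2ccccc2)c(=O)c2ccc(Cl)nc21` gives 540 nM, the lowest of the two numbers so far; compound 1 `C#CCn1cc(C(=O)NC(CC(=O)Nc2ccccn2)c2ccccc2)c(=O)c2ccc(Cl)nc21` gives 1700 nM, and the step of a 3.1-fold lower number from compound 1 to compound 2 (0.50 log units; beyond the scatter) is a modest change at the amide-type nitrogen. Compound 3 `C#CCn1cc(C(=O)NC(CC(=O)NC2CCCC2)c2ccccc2)c(=O)c2ccc(Cl)nc21` differs from compound 2 by cyclopentyl in place of phenyl on an amide-type nitrogen. Among the measured compounds shown here, no measured step bears on replacing a six-membered aromatic ring with a five-membered non-aromatic ring at this site; the one known step there concerns pyridin-2-yl against phenyl. For compound 3 a step of about a 1.5-fold higher number from compound 2 to compound 3 (0.17 log units; within the scatter) in this assay is expected, near the scatter. Compound 3 is estimated at 800 nM, range 250 nM to 3000 nM.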

Compound 3, half-maximal inhibitory concentration: 1100 nM
Estimate against measurement, compound 3: 1.4-fold (0.14 log units) below, within the range that was stated.
By their numbers in this assay, from the lowest: compound 2; then compounds 3 and 1 (each within the scatter of the next).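

At the amide-type nitrogen in this assay, cyclopentyl is the only non-aromatic ring shown, and the cost of losing phenyl is modest: a 2.0-fold higher number from compound 2 to compound 3 (0.31 log units; beyond the scatter). Against pyridin-2-yl, the reading is a 1.5-fold lower number from compound 1 to compound 3 (0.19 log units; within the scatter), so these two groups are not separated and an aromatic ring is not required for activity at this level. Nothing at hand explains these differences. Still open, from the compounds shown here alone, is how an open-chain group such as isobutyl compares with cyclopentyl on this nitrogen. Also open, going by these compounds, is whether a piperidin-4-yl ring or a benzyl group would match phenyl.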